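Nitro in Place of Ethoxycarbonyl: An Expected Outcome

This account rests on a few compounds, and the source may have more. Where it says the series, first, only, none or still open, it means among the compounds named here.

Of the compounds shown here, three sharing one core have been measured in a functional assay on ileum (strain Hartley) for agonist activity at 5-hydroxytryptamine receptor 3A (Cavia porcellus); a lower number here means a less potent compound, a higher number a more potent compound, by a factor of ten per unit of this negative logarithm. Compound 1 `CC(C)c1cccc2nc(N3CCN(C)CC3)oc12` gives < 4, a limit of the assay rather than a number. Compound 2 `CCOC(=O)c1ccc2oc(N3CCN(C)CC3)nc2c1` likewise gives only a limit, < 4. Compound 3 `Cc1cc(Cl)c2oc(N3CCN(C)CC3)nc2c1` gives 6.22. Among the compounds with values here, compound 2 therefore stands at the limit of < 4 in this assay, at which 2 of the 3 values shown sit, and no pair of measured compounds differs in a single place, so no measured step is available to guide the next one. Compound 4 `CN1CCN(c2nc3cc([N+](=O)[O-])ccc3o2)CC1` differs from compound 2 by nitro in place of ethoxycarbonyl on an aromatic carbon. For compound 4 a modest rise in this assay is expected, though possibly one not beyond the scatter, with an estimated 4.6 and a range from 3.8 to 5.6. The expected step is then a number at least 0.60 log units higher from compound 2 to compound 4 (beyond the scatter).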

Compound 4, negative logarithm of the half-maximal effective concentration: 6.1
The estimate for compound 4 lay 1.50 log units below the measured number; the measured number lies above the stated range.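

Compound 2 gives only a limit of the assay, not a number: the limit of < 4 in this assay, at which 2 of the 4 values shown sit. In this assay, within the data shown here, placing nitro instead of ethoxycarbonyl on this aromatic carbon gives a number at least 2.10 log units higher from compound 2 to compound 4 (beyond the scatter), the first single-place change that can be read. The earlier compounds shown here did not show that this change alone can carry the shared core from a limit to a measured value.

The compounds shown leave open how an amine or a carboxylic acid on this carbon would read. On these data alone, the full size of the step also stays open, as it rests on a limit.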